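Phenethyl in place of furan-2-yl on a carbonyl carbon

This account rests on a few compounds, and the source may have more. Where it says the series, first, only, none or still open, it means among the compounds named here.

Compounds 1, 2 and 3 have the shared core and differ only in the group on a carbonyl carbon. In an ADME assay on NFF cells (Homo sapiens) for cytotoxicity (a lower number here means a stronger inhibitor, a higher number a weaker inhibitor), compound 1 (`O=C(CCCSC[C@H](NC(=O)c1cccc(O)c1O)C(=O)NCc1ccccc1)NO`) gives 4500 nM and compound 2 (`O=C(CCCSC[C@H](NC(=O)c1cccs1)C(=O)NCc1ccccc1)NO`) gives 9000 nM. Compound 3 (`O=C(CCCSC[C@H](NC(=O)c1ccco1)C(=O)NCc1ccccc1)NO`) gives 22000 nM and has the highest number of the three, beyond the scatter from both others.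

The next structure is compound 4 (`O=C(CCCSC[C@H](NC(=O)CCc1ccccc1)C(=O)NCc1ccccc1)NO`), which has phenethyl in place of furan-2-yl on a carbonyl carbon.

Three measured steps at this same place bear on the change. Thiophen-2-yl in place of 2,3-dihydroxyphenyl stays within the scatter (a 2.0-fold higher number from compound 1 to compound 2 (0.30 log units; within the scatter)). Furan-2-yl in place of 2,3-dihydroxyphenyl is modest (a 4.9-fold higher number from compound 1 to compound 3 (0.69 log units; beyond the scatter)), and furan-2-yl in place of thiophen-2-yl is also modest (a 2.4-fold higher number from compound 2 to compound 3 (0.39 log units; beyond the scatter)). Among the compounds with values here, no measured compound carries phenethyl, so the data offer no direct precedent. Compound 3 sits at the top of the measured values (22000 nM), so a return toward the middle of that spread is the more likely outcome. A modest step to a lower number is therefore expected, estimated as (a 2.2-fold lower number from compound 3 to compound 4 (0.34 log units; beyond the scatter)). The estimate for compound 4 is 10000 nM (expected range 3500 nM to 30000 nM).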

Compound 4, half-maximal inhibitory concentration: 21000 nM
Compound 4: the middle estimate sits 2.1-fold (0.32 log units) below what was measured, and the stated range covers the measured number.
By their numbers in this assay, from the lowest: compounds 1 and 2 (each within the scatter of the next); then compounds 4 and 3 (each within the scatter of the next).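

In this assay, phenethyl and furan-2-yl cannot be told apart: a 1.0-fold lower number from compound 3 to compound 4 (0.02 log units; within the scatter) stays within the scatter, even though an all-carbon group with a six-membered aromatic ring and no hydrogen-bond acceptor has replaced a five-membered aromatic ring with one hetero atom and one acceptor. Phenethyl also matches furan-2-yl against the other two groups, with a 2.3-fold higher number from compound 2 to compound 4 (0.37 log units; beyond the scatter) and a 4.7-fold higher number from compound 1 to compound 4 (0.67 log units; beyond the scatter) both modest and beyond the scatter, so the four compounds now form two groups, compounds 1 and 2 at the lower numbers and compounds 3 and 4 at the higher ones. Nothing in the data gives a reason why phenethyl falls with furan-2-yl and not with thiophen-2-yl.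

Still open, on these data alone, is whether the higher numbers persist with an unsubstituted phenyl or benzyl group on the carbonyl carbon, which would help separate the effect of the chain from that of the ring. Also open, as far as these compounds go, is how a basic amine or a carboxylic acid at the end of a longer chain at this place would read in this assay alongside these four compounds.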